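Furan for Thiophene on a Shared Nucleoside Core

The source may report more compounds than this note shows. Statements on the series, on what has been measured and on what is new or still open speak of the compounds shown alone.

Measured so far:
compound 1, `Nc1nc(N)c2c(-c3ccsc3)cn([C@@H]3O[C@H](CO)[C@@H](O)[C@H]3O)c2n1`, gives > 20000 nM
compound 2, `Nc1nc2c(c(-c3ccccc3)cn2[C@@H]2O[C@H](CO)[C@@H](O)[C@H]2O)c(=O)[nH]1`, gives > 20000 nM

Both compounds were tested in a functional assay on HL-60 cells (Homo sapiens) for antiproliferative activity, read by XTT assay, with a stated time of 72 h; a higher number here means a weaker inhibitor, a lower number a stronger inhibitor. For compound 1 the value > 20000 nM is a limit of the assay rather than a number. For compound 2 the value > 20000 nM is likewise a limit. Among the compounds with values here, compound 1 therefore stands at the limit of > 20000 nM in this assay, at which 2 of the 2 values shown sit; no compound in this set has a measured number at all, so there is no gauge for how much any change moves the read-out.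

Compound 3, `Nc1nc(N)c2c(-c3ccoc3)cn([C@@H]3O[C@H](CO)[C@@H](O)[C@H]3O)c2n1`, differs from compound 1 in one place: furan-3-yl in place of thiophen-3-yl on an aromatic carbon. No step between measured compounds is shown, so the size of this change can only be guessed. Since compound 1 already sits at the limit of this assay, the expected step that the limit leaves unreadable from compound 1 to compound 3 is none beyond the usual scatter, and compound 3 is most likely to return a limit as well. As a best estimate, compound 3 is expected to give 40000 nM in this assay, with a range from 8000 nM to 200000 nM.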

Compound 3, half-maximal inhibitory concentration: > 20000 nM
Compound 3: a limit, no number (the forecaster's own chance of this, stated with the estimate: 85%); the middle value lies beyond the limit too.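

In this assay compound 3 gives > 20000 nM, which is a limit and not a number. Within the data shown here, compound 1 also stands at a limit, so no step for furan-3-yl in place of thiophen-3-yl can be read between compound 1 and compound 3, as all the values shown are limits: the limit of > 20000 nM in this assay, at which 3 of the 3 values shown sit. The compounds shown leave open whether any change on the shared core would give a measured number in this assay.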